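This account rests on a few compounds, and the source may have more. Where it says the series, first, only, none or still open, it means among the compounds named here.

Working notes on the series, read in an ADME assay on the whole organism (Rattus norvegicus, strain Sprague-Dawley) for pharmacokinetics, using cassette dosing, at a dose of 1 mg/kg by the oral route; on this read-out lower numbers stand for lower oral bioavailability and higher numbers for higher oral bioavailability. Compound 1 `O=C(Nc1ccc2[nH]c(=O)oc2c1)C(=O)N1CCN(c2ccc(F)cc2)CC1` gives 39.3%. Compound 2 `O=C(Nc1ccc2[nH]c(=O)oc2c1)C(=O)N1CCN(c2ccc(Cl)c(F)c2)CC1` gives 28.2%. Compound 3 `COc1ccc(N2CCN(C(=O)C(=O)Nc3ccc4[nH]c(=O)oc4c3)CC2)cc1F` gives 0.6%. Compound 2 therefore stands second highest of the three, lower than compound 1 and higher than compound 3.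

The next compound to read is compound 4 `C[C@@H]1CN(C(=O)C(=O)Nc2ccc3[nH]c(=O)oc3c2)CCN1c1ccc(Cl)c(F)c1`. Its difference from compound 2 is methyl in place of hydrogen on a saturated ring carbon, next to the ring atom that bears a 4-chloro-3-fluorophenyl group.

Three measured steps are available. a number 11.1 percentage points lower from compound 1 to compound 2 (beyond the scatter) is modest, a number 38.7 percentage points lower from compound 1 to compound 3 (beyond the scatter) is large and a number 27.6 percentage points lower from compound 2 to compound 3 (beyond the scatter) is modest. All three change the aryl group on the ring nitrogen, and none changes the saturated ring itself, so none measures this methyl directly. They show only that this assay can move well beyond the scatter within this small set. For the measured compounds named here, with no ring-substituted compound yet measured, no direction can be favoured, and no step beyond the scatter is expected. The estimated step of a number 0.2 percentage points lower from compound 2 to compound 4 (within the scatter) reflects that expectation. For compound 4 the expected value is 28%. The expected range runs from 10% to 48%, kept wide on purpose.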

Compound 4, oral bioavailability: 32%
For compound 4 the middle estimate is 4 percentage points below the measured one; measured number inside the range.
By their numbers in this assay, from the lowest: compound 3; then compounds 2, 4 and 1 (each within the scatter of the next, the first and the last beyond it).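

In this assay, for the compounds shown here, methyl in place of hydrogen on a saturated ring carbon gives a number 3.8 percentage points higher from compound 2 to compound 4 (within the scatter), the only step in this set that touches the saturated ring, as the earlier steps all change the aryl group on the ring nitrogen. With the 4-chloro-3-fluorophenyl group in place, this position, next to the ring nitrogen and next to the ring atom that bears that group, therefore accepts a methyl with no shift in oral bioavailability that can be told from the scatter, unlike the aryl changes among compounds 1, 2 and 3, which all moved the number beyond it. Nothing at hand bears on why the number holds at this position.

From the compounds shown here alone, this reading rests on a single pair with one spatial arrangement of the methyl, so the mirror-image arrangement, and the same methyl with the 4-fluorophenyl group of compound 1 or the 3-fluoro-4-methoxyphenyl group of compound 3, remain open. Also open, going by these compounds, is whether a larger or functionalised group on this carbon, such as an ethyl, a hydroxymethyl or an aminomethyl, would stay within the scatter as well.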